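Lengthening the alkyne chain on the coumarin ester core

A few compounds are considered here, and "the series" means these few. Any claim that something is new, unique, unknown or untested is made for them only; others in the source may bear on it.

In an assay on cells for inhibition of Amine oxidase [flavin-containing] A (Homo sapiens), read by Amplex Red, with stated times of 30 min and 45 min (on this read-out higher numbers stand for weaker inhibition and lower numbers for stronger inhibition), the measured compounds stand as follows.
Compound 1 `C#CCCCOc1ccc2oc(=O)c(C(=O)OC)cc2c1` gives > 10000 nM, which is a limit of the assay and not a number.
Compound 2 `C#CCCCOc1ccc2cc(C(=O)Nc3ccc(F)cc3)c(=O)oc2c1` gives > 10000 nM, likewise a limit of the assay.
Compound 3 `C#CCCCOc1ccc2cc(NC(C)=O)c(=O)oc2c1` gives 930 nM.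

Compound 1 thus stands at the weak end of what the assay reports: it sits at the limit of > 10000 nM in this assay, at which 2 of the 3 values shown sit, and only compound 3 returns an actual number. No pair among these three differs in a single place, so no measured step is available to guide the next change.

Compound 4 `C#CCCCCOc1ccc2oc(=O)c(C(=O)OC)cc2c1` differs from compound 1 by propargyl in place of ethynyl on a saturated chain carbon, three bonds along the chain from an oxygen on an aromatic ring. The ester and the shared core are untouched; only the chain grows by one carbon.

Since compound 1 is itself a limit, the step from compound 1 to compound 4 in this assay is expected to be small, within the scatter or none at all, as shown by a step that the limit leaves unreadable from compound 1 to compound 4. Compound 4 is therefore estimated at 12000 nM, in the range 3000 nM to 40000 nM, and the assay is most likely to return only a limit for it again.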

Compound 4, half-maximal inhibitory concentration: > 10000 nM
Compound 4: a limit, no number (the forecaster's own chance of this, stated with the estimate: 70%); the middle value does not contradict the limit.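

In this assay compound 4 gives > 10000 nM, which is a limit of the assay and not a number. Going by these compounds alone, compound 1 is also a limit there, so no step between compound 1 and compound 4 can be read: the limit of > 10000 nM in this assay, at which 3 of the 4 values shown sit.

The compounds shown leave open whether lengthening the alkyne chain on the ester core changes inhibition at all.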